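Indole-oxazole series: replacing the aryl group with piperidine

The source may hold more compounds than are shown below. What is called first, only, known or untested is meant among the compounds shown, and "the series" means these compounds.

Measured so far in a functional assay on DU-145 cells (Homo sapiens) for cytotoxicity, read by MTT assay, with a stated time of 48 h; a lower number here means a stronger inhibitor, a higher number a weaker inhibitor:
compound 1 `COc1ccc(-c2nc(-c3c[nH]c4ccccc34)co2)cc1OC`: 300000 nM
compound 2 `Fc1ccc(-c2nc(-c3c[nH]c4ccccc34)co2)cc1`: 31800 nM
compound 3 `C(=C/c1nc(-c2c[nH]c3ccccc23)co1)\c1ccccc1`: 135000 nM

Compound 2 gives the lowest number of the three in this assay, and its gaps to compound 3 and to compound 1 both lie beyond the scatter. Compound 4 `c1ccc2c(-c3coc(C4CCNCC4)n3)c[nH]c2c1` is not yet measured; it differs from compound 2 by piperidin-4-yl in place of 4-fluorophenyl on an aromatic carbon. Among the compounds with values here, no step between measured compounds matches this change, so the expectation rests on the three values alone. The shared core is kept, and the replaced group is the only one altered. A step from compound 2 to compound 4 toward a higher number, of moderate size, is expected, a 2.2-fold higher number from compound 2 to compound 4 (0.34 log units; beyond the scatter). Compound 4 is estimated at 70000 nM, within 15000 nM to 300000 nM.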

Compound 4, half-maximal inhibitory concentration: 381000 nM
Compound 4: middle estimate off by 5.4-fold (0.74 log units), on the low side; the measured number lies above the stated range.
By their numbers in this assay, from the lowest: compound 2; then compound 3; then compounds 1 and 4 (each within the scatter of the next).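

In this assay, within the data shown here, piperidin-4-yl in place of 4-fluorophenyl gives a 12-fold higher number from compound 2 to compound 4 (1.08 log units; beyond the scatter), the first step that can be read directly at this position. A six-membered non-aromatic ring with a hetero atom, bringing a hydrogen-bond donor and acceptor, is therefore no equal replacement here for the aromatic carbon ring of compound 2.

As far as these compounds go, whether the step follows the ring nitrogen or the non-aromatic ring remains open, and cyclohexyl or pyridin-4-yl at this position would separate the two. No measurement at hand accounts for the size of the step.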